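Fluorine pattern changes on the aryl piperazine of a thiophene core

The compounds below may be only part of what the source reports. "The series", "measured", "known", "first", "only" and "open" are said of these compounds alone.

Measured compounds:
compound 1, `Nc1scc(CN2CCN(c3ccc(C(F)(F)F)cc3)CC2)c1C(=O)c1cccc(C(F)(F)F)c1`, -47%
compound 2, `Nc1scc(CN2CCN(c3cccc(F)c3)CC2)c1C(=O)c1cccc(C(F)(F)F)c1`, -62%

Both compounds share one core and differ only in the aromatic group on an amine nitrogen in a ring. In a functional assay on CHO cells with adenosine receptor A1 (Homo sapiens) as the target, read by cAMP accumulation and immunoassay, with a stated time of 6 min, tested at 10 uM (a higher number here means a weaker effect of the compound at the concentration tested, a lower number a stronger effect), compound 1 gives -47%, and compound 2 gives -62%. Of these two numbers compound 2 stands lowest, so it shows the stronger effect at the tested concentration. Going by the values given here, the one measured step, a number 15 percentage points lower from compound 1 to compound 2 (beyond the scatter), is modest but beyond the scatter.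

Compound 3, `Nc1scc(CN2CCN(c3c(F)cccc3F)CC2)c1C(=O)c1cccc(C(F)(F)F)c1`, is not yet measured. It differs from compound 2 as follows: 2,6-difluorophenyl in place of 3-fluorophenyl on an amine nitrogen in a ring. This is a change at the same place as the measured step, yet of a different kind: one fluorine is kept and a second added, while the ring's substitution pattern shifts. The measured step only tells that this place tolerates changes, with a modest effect. The step expected from compound 2 to compound 3 in this assay is therefore none beyond the scatter, a number 7 percentage points higher from compound 2 to compound 3 (within the scatter). Compound 3 is estimated at -55%, with a range from -80% to -30%.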

Compound 3, a percentage reported as activity, at one concentration (the size of the read-out at that concentration, not a potency): 4%
Beside the measured number, compound 3's estimate is 59 percentage points below it, outside the stated range (above it).
By their numbers in this assay, from the lowest: compound 2; then compound 1; then compound 3.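

Until now this place, on an amine nitrogen in a ring, looked forgiving, yet in this assay the change to 2,6-difluorophenyl gives a number 66 percentage points higher from compound 2 to compound 3 (beyond the scatter), which shows the position to be far more sensitive than the earlier step suggested. The comparison with the 4-(trifluoromethyl)phenyl group points the same way, with a number 51 percentage points higher from compound 1 to compound 3 (beyond the scatter), so at the tested concentration compound 3 has the weakest effect of the three, at 4%. The groups themselves differ only slightly, by one further fluorine and a changed pattern on the same six-membered aromatic ring, so here a small edit to the structure goes with a large change in the read-out.

No measurement at hand bears on what lies behind this drop, so it stays unexplained. On these data alone, whether the second fluorine or the new pattern accounts for the drop also stays open, as does how a phenyl group without fluorine or a methoxyphenyl group would behave at this place.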